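Notes on a phenol-to-ether step in the series

A few compounds are considered here, and "the series" means these few. Any claim that something is new, unique, unknown or untested is made for them only; others in the source may bear on it.

Measured so far:
compound 1, `CCC(C)(C)Cc1c[nH]c(CCc2ccc(-c3ccccc3O)cc2)n1`: in a functional assay for agonist activity at Bombesin receptor subtype-3 (Homo sapiens) (a lower number here means that less compound is needed, a higher number that more compound is needed for the effect), compound 1 gives 133 nM
compound 2, `O=C1NC(=O)C(c2ccccc2-c2ccc(CCC3N=CC(CC4CCCC4)=N3)cc2)S1`: in this assay compound 2 gives 1770 nM

Compound 1 holds the lowest of the two numbers in this assay. The nearest, compound 2, sits at a higher number, and that gap lies beyond the scatter. Going by the values given here, compound 2 is built on a different core, so no single-change step between measured compounds exists; the two values show only that the core of compound 1 is the one with the lower number.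

Compound 3, `CCC(C)(C)Cc1c[nH]c(CCc2ccc(-c3ccccc3OCc3ncn[nH]3)cc2)n1`, differs from compound 1 in one place: (1H-1,2,4-triazol-5-yl)methyl in place of hydrogen on an oxygen on an aromatic ring. Among the compounds with values here, no measured pair isolates this change, so the expectation rests on compound 1 alone. A step of modest size is expected, most likely towards a higher number in this assay, but possibly none beyond the scatter. The step expected from compound 1 to compound 3 in this assay is a 1.9-fold higher number from compound 1 to compound 3 (0.27 log units; within the scatter). Compound 3 is estimated at 250 nM, with a range from 60 nM to 1200 nM.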

Compound 3, half-maximal effective concentration: 172 nM
Compound 3: middle estimate off by 1.5-fold (0.16 log units), on the high side; low and high end bracket the measured number.
By their numbers in this assay, from the lowest: compounds 1 and 3 (each within the scatter of the next); then compound 2.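

The oxygen on the aromatic ring of compound 1 now has its first single-change step: in this assay, (1H-1,2,4-triazol-5-yl)methyl in place of hydrogen gives a 1.3-fold higher number from compound 1 to compound 3 (0.11 log units; within the scatter). The hydrogen on this oxygen is therefore not needed to keep the number in this range, and an entering group of 6 heavy atoms, with one five-membered aromatic ring with 3 hetero atoms, leaves the read-out within the scatter. This holds for this one group on the core of compound 1 and cannot yet be called a rule for the position, and no measurement shown here gives a reason for it.

Still open, as far as these compounds go, is whether the ring itself matters or whether any ether at this oxygen behaves alike: a plain methyl ether, a carboxylic acid joined through a methylene, or an amine on a longer chain would separate these cases. Also open, from the compounds shown here alone, is whether the step stays this small when the shared core is changed elsewhere, for example in the alkyl group on the other side of the molecule.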